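Acetyl Capping of an Aromatic Amine in a Transporter Series

The source may hold more compounds than are shown below. What is called first, only, known or untested is meant among the compounds shown, and "the series" means these compounds.

Compound 1 `C=CCCCCCCCCOc1ccc2c(c1)S(=O)(=O)C[C@@](CC)(CCCC)[C@H](O)[C@@H]2c1ccccc1`: 16000 nM
Compound 2 `CCCC[C@]1(CC)CS(=O)(=O)c2ccc(N)cc2[C@@H](c2ccccc2)[C@H]1O`: 68 nM

In an assay on cells for inhibition of ileal sodium/bile acid cotransporter (Homo sapiens) (on this read-out lower numbers stand for stronger inhibition and higher numbers for weaker inhibition), compound 1 gives 16000 nM, whereas compound 2 gives 68 nM. Going by the values given here, compound 2 therefore stands lowest of the two numbers; its only neighbour is compound 1, whose number lies far higher, a gap well beyond the scatter. Among the compounds with values here, the two compounds differ in several places at once, so their values show only that compound 2 is the stronger inhibitor.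

Compound 3 `CCCC[C@]1(CC)CS(=O)(=O)c2ccc(NC(C)=O)cc2[C@@H](c2ccccc2)[C@H]1O` has not yet been measured. Within the data shown here, its single difference from compound 2 is this: acetyl in place of hydrogen on a nitrogen on an aromatic ring. Among the measured compounds shown here, no measured pair shows a change of this kind, so there is no direct guide. In this assay the step is expected to be small, pointing toward a weaker inhibitor, roughly at the edge of the scatter. The estimated step from compound 2 to compound 3 is a 2.2-fold higher number from compound 2 to compound 3 (0.34 log units; beyond the scatter). Compound 3 is expected to give about 150 nM, within a range from 40 nM to 600 nM.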

Compound 3, half-maximal inhibitory concentration: 90 nM
Compound 3: the middle estimate sits 1.7-fold (0.22 log units) above what was measured; the range from low to high includes it.
By their numbers in this assay, from the lowest: compounds 2 and 3 (each within the scatter of the next); then compound 1.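

In this assay, replacing hydrogen with acetyl on the nitrogen on the aromatic ring gives a 1.3-fold higher number from compound 2 to compound 3 (0.12 log units; within the scatter), so this read-out does not separate compound 2 from compound 3. Going by these compounds alone, this is the first comparison here in which only one place differs, and it shows that the change from amino to acetamido at this position leaves inhibition in the same range. No measurement is available to explain this outcome.

Still open, on these data alone, is whether the same holds for other groups on this nitrogen, such as a benzoyl group, a longer acyl chain or a chain ending in a carboxylic acid. Also open, as far as these compounds go, is whether the nitrogen is needed at all, a question that a methoxy group in place of the amino group could answer.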